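The source may hold more compounds than are shown below. What is called first, only, known or untested is meant among the compounds shown, and "the series" means these compounds.

Measured so far:
compound 1 `Cc1cc(C#N)cc(C)c1Sc1ccnc(Nc2ccc(C#N)cc2)n1`: 2.06
compound 2 `Cc1cc(C)c(Sc2ccnc(Nc3ccc(C#N)cc3)n2)c(C)c1`: 2.16
compound 3 `Cc1cc(C#N)cc(C)c1Nc1nc(Nc2ccc(C#N)cc2)ncc1C#N`: 1.06

In a physicochemical assay for lipophilicity (on this read-out higher numbers stand for higher lipophilicity and lower numbers for lower lipophilicity), compound 3 gives the lowest value of the three, and its gaps to compound 1 and to compound 2 both lie beyond the scatter. Compound 1 and compound 2 differ in one place, (methyl in place of cyano on an aromatic carbon), and the step was a number 0.10 log units higher from compound 1 to compound 2 (within the scatter). Compound 4 `Cc1cc(C)c(Nc2nc(Nc3ccc(C#N)cc3)ncc2C#N)c(C)c1` stands to compound 3 as compound 2 stands to compound 1: methyl in place of cyano on an aromatic carbon. The surroundings of the exchange read the same in both pairs, so this is the same change on a different core; the difference between the core of compound 1 and the core of compound 3 is not broken down here. Because the earlier step was a number 0.10 log units higher from compound 1 to compound 2 (within the scatter), the step from compound 3 to compound 4 in this assay is expected to be a number 0.10 log units higher from compound 3 to compound 4 (within the scatter). Compound 4 is accordingly estimated at 1.16, most likely between 0.86 and 1.46.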

Compound 4, partition coefficient: 1.49
The estimate for compound 4 lay 0.33 log units below the measured number, and the stated range ends below it.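

In this assay, methyl in place of cyano on an aromatic carbon gave a number 0.43 log units higher from compound 3 to compound 4 (beyond the scatter) on the core of compound 3, set against a number 0.10 log units higher from compound 1 to compound 2 (within the scatter) on the core of compound 1. The step therefore did not carry over at one size between these two cores: it lies beyond the scatter on one and within the scatter on the other. With one pair per core, this does not show how the step would read on a further core, and no evidence at hand accounts for the difference between the two pairs.

The compounds shown leave open how an amine, a carboxylic acid or a longer chain on that aromatic carbon would read on either core. They also leave open whether such groups would differ between the two cores as methyl and cyano do.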